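The source may hold more compounds than are shown below. What is called first, only, known or untested is meant among the compounds shown, and "the series" means these compounds.

Measured so far:
compound 1, `CC(c1ccc(-c2ccccc2)c(F)c1)c1nnc2n1N=C(c1ccc(Cl)cc1)CS2`: 3800 nM
compound 2, `CC(C)Cc1ccc(C(C)c2nnc3n2N=C(c2ccc(OC(F)(F)F)cc2)CS3)cc1`: 6400 nM

In a functional assay on Hep 3B2 cells (Homo sapiens) for inhibition, read by sulforhodamine B assay, with a stated time of 72 h (on this read-out higher numbers stand for weaker inhibition and lower numbers for stronger inhibition), compound 1 holds the lowest of the two numbers, though compound 2 sits within the scatter of it, so the two are not separated. Compound 3, `CC(c1ccc(-c2ccccc2)c(F)c1)c1nnc2n1N=C(c1ccc(Br)cc1)CS2`, differs from compound 1 by bromo in place of chloro on an aromatic carbon. Among the measured compounds shown here, no measured pair here varies at that site, so the size of the step rests on general expectation only. A shift of no more than the scatter is expected, with no preferred direction; the expected step is a 1.1-fold lower number from compound 1 to compound 3 (0.04 log units; within the scatter). Compound 3 is therefore estimated at 3500 nM, within a range from 1500 nM to 8000 nM.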

Compound 3, half-maximal inhibitory concentration: 1500 nM
Estimate against measurement, compound 3: 2.3-fold (0.37 log units) above, and the stated range covers the measured number.
By their numbers in this assay, from the lowest: compound 3; then compounds 1 and 2 (each within the scatter of the next).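

In this assay, among the compounds shown here, the change from 4-chlorophenyl to 4-bromophenyl gives a 2.5-fold lower number from compound 1 to compound 3 (0.40 log units; beyond the scatter) and is the first step that can be read, so this aromatic carbon, para to a large group, responds to a swap of one halogen for another. The step is modest and rests on a single pair, and no available data explain it. Open, as far as these compounds go, is whether iodo, a methoxy group or an amine at this position would extend the step, hold it or reverse it. Also open, from the compounds shown here alone, is whether bromo in place of chloro gives a similar step when the rest of the molecule differs from compound 1.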